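The source may report more compounds than this note shows. Statements on the series, on what has been measured and on what is new or still open speak of the compounds shown alone.

Measured so far:
compound 1, `O=[N+]([O-])c1ccc(C2=NOC(c3ccc(-c4cccnc4)cc3)C2)o1` — > 50000 nM
compound 2, `O=[N+]([O-])c1ccc(C2=NOC(c3ccc(N4CCN(Cc5cccnc5)CC4)cc3)C2)o1` — > 50000 nM

Of the compounds shown here, two have been tested in an ADME assay on WI-38 cells (Homo sapiens) for cytotoxicity, read by MTT assay, with a stated time of 96 h; a lower number here means a stronger inhibitor, a higher number a weaker inhibitor. Compound 1 `O=[N+]([O-])c1ccc(C2=NOC(c3ccc(-c4cccnc4)cc3)C2)o1` shows no measurable effect: its reading of > 50000 nM is a limit of the assay, not a number. Compound 2 `O=[N+]([O-])c1ccc(C2=NOC(c3ccc(N4CCN(Cc5cccnc5)CC4)cc3)C2)o1` likewise gives only a limit, > 50000 nM. So compound 1 stands at the upper edge of what this assay can report, and the only other reading sits at the same edge, as the limit of > 50000 nM in this assay, at which 2 of the 2 values shown sit, records. Among the compounds with values here, no step between measured compounds can be drawn from this.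

Compound 3 `O=[N+]([O-])c1ccc(C2=NOC(c3ccc(-c4ccccn4)cc3)C2)o1` is the next compound, not yet measured in this assay. It differs from compound 1 by pyridin-2-yl in place of pyridin-3-yl on an aromatic carbon. With both known readings stuck at the limit, the step expected from compound 1 to compound 3 is a step that the limit leaves unreadable from compound 1 to compound 3, none beyond the scatter in either direction. Compound 3 is therefore expected to come out near 60000 nM, within roughly 20000 nM to 200000 nM, most likely again as a limit rather than a number.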

Compound 3, half-maximal inhibitory concentration: > 50000 nM
Compound 3 ended at the assay's limit; the forecaster's own chance of this, stated with the estimate: 80%; the middle value does not contradict the limit.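

Compound 1 and compound 3 both end at a limit and not at a number, so no step can be read between them, and the same holds for all the compounds shown: the limit of > 50000 nM in this assay, at which 3 of the 3 values shown sit. The compounds shown leave open whether pyridin-2-yl and pyridin-3-yl differ at all, and which change to the shared core would give a number.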